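The source may hold more compounds than are shown below. What is called first, only, known or untested is meant among the compounds shown, and "the series" means these compounds.

In a functional assay on HeLa cells (Homo sapiens) for inhibition, read by sulforhodamine B assay (on this read-out lower numbers stand for stronger inhibition and higher numbers for weaker inhibition), compound 3 `O=C1C(N2CCC2)=CC(=O)c2c1nc1n2[C@H]2OC[C@@H](O)[C@H]2OC1` gives > 16000 nM, which is a limit and not a number. Compound 1 `O=C1C(NC2CCCC2)=CC(=O)c2c1nc1n2[C@H]2OC[C@@H](O)[C@H]2OC1` gives > 16000 nM, also a limit. Compound 2 `COc1ccc(NC2=CC(=O)c3c(nc4n3[C@H]3OC[C@@H](O)[C@H]3OC4)C2=O)cc1` gives > 8000 nM, again a limit. Within the data shown here, no compound here therefore has a measured number, and compound 3 can be placed only by its limit.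

Compound 4 `COc1cccc(NC2=CC(=O)c3c(nc4n3[C@H]3OC[C@@H](O)[C@H]3OC4)C2=O)c1` carries (3-methoxyphenyl)amino in place of azetidin-1-yl on a double-bonded ring carbon. The closest guide is a step that the two limits leave unreadable from compound 2 to compound 3, which links azetidin-1-yl with (4-methoxyphenyl)amino at the same place. Two further steps also bear on the question, a step that the two limits leave unreadable from compound 1 to compound 3 and a step that the two limits leave unreadable from compound 1 to compound 2. None of the three has a readable size, so they give no support for expecting a gain or a loss.

The expected change is an at least 1.1-fold lower number from compound 3 to compound 4 (0.05 log units; that floor lies within the scatter), with no step beyond the usual scatter foreseen in this assay. Compound 4 is estimated at 14000 nM, with an expected range from 5000 nM to 30000 nM, and the result may well be another limit.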

Compound 4, half-maximal inhibitory concentration: > 8000 nM
Compound 4: a limit, no number; the forecaster's own chance of this, stated with the estimate: 85%; the middle value lies beyond the limit too.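

Compound 4 gives only a limit, as do compound 1, compound 2 and compound 3, so none of the steps from these three to compound 4 can be read. The compounds shown leave open whether any of these amine groups changes the result in this assay.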